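Ortho substituent on the distal phenyl: methoxy replacing isopropyl

The compounds below may be only part of what the source reports. "The series", "measured", "known", "first", "only" and "open" are said of these compounds alone.

Among the measured compounds shown here, compound 2 `CC(C)c1ccccc1-c1cccc(CNc2ccc(OCC(=O)O)c(F)c2)c1` gives, in a functional assay on CHO cells for agonist activity at Free fatty acid receptor 1 (Homo sapiens), read by FLIPR and calcium flux (a higher number here means that more compound is needed for the effect, a lower number that less compound is needed), a value of 86.2 nM, the highest of the two numbers measured so far. Its nearest neighbour is compound 1 `O=C(O)COc1ccc(NCc2cccc(-c3ccccc3F)c2)cc1F`, which in this assay gives 36.5 nM. For the measured compounds named here, the one measured step, a 2.4-fold higher number from compound 1 to compound 2 (0.37 log units; beyond the scatter), is the only change made at this aromatic carbon, and it bears directly on the next step: compound 3 `COc1ccccc1-c1cccc(CNc2ccc(OCC(=O)O)c(F)c2)c1` differs from compound 2 by methoxy in place of isopropyl on an aromatic carbon. A move from fluoro to isopropyl cost a modest amount; methoxy is a third option at the same position, with nothing measured on it. The step from compound 2 to compound 3 in this assay is therefore expected to be small, plausibly back toward compound 1, giving a 1.6-fold lower number from compound 2 to compound 3 (0.20 log units; within the scatter). Compound 3 is estimated at 55 nM, with a range of 25 nM to 120 nM in this assay.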

Compound 3, half-maximal effective concentration: 536 nM
For compound 3 the middle estimate is 9.7-fold (0.99 log units) below the measured one; measured number outside the range, above it.
By their numbers in this assay, from the lowest: compound 1; then compound 2; then compound 3.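

In this assay, methoxy, with fewer heavy atoms than isopropyl, is the poorest of the three groups at this aromatic carbon (a 6.2-fold higher number from compound 2 to compound 3 (0.79 log units; beyond the scatter)), and its loss against fluoro is large (a 15-fold higher number from compound 1 to compound 3 (1.17 log units; beyond the scatter)). The position therefore separates these groups far more sharply than the modest first change suggested (a 2.4-fold higher number from compound 1 to compound 2 (0.37 log units; beyond the scatter)), and among the compounds shown, a smaller heavy-atom count at this carbon does not go with a lower number, as isopropyl and methoxy show. No supporting data explain this loss.

As far as these compounds go, it remains open whether the loss follows the oxygen of methoxy or the group as a whole; methyl, ethyl, hydroxyl and ethoxy at this carbon are the obvious comparisons. From the compounds shown here alone, whether the same order of groups holds on a changed core also remains open.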